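This account rests on a few compounds, and the source may have more. Where it says the series, first, only, none or still open, it means among the compounds named here.

Measured in a physicochemical assay for lipophilicity, using the shake flask method, in phosphate buffer, measured as octanol-water partition, at pH 7.4; a lower number here means a more polar compound, a higher number a more lipophilic compound:
- compound 1 `CC[C@@H](c1ccc(C(=O)O)c(Oc2cccc(Cl)c2)c1F)N1CCC[C@H](n2cc(C)c(=O)[nH]c2=O)C1`: 0.11
- compound 2 `CC[C@H](c1ccc(C(=O)O)c(Oc2cccc(Cl)c2)c1OC)N1CCC[C@H](n2cc(C)c(=O)[nH]c2=O)C1`: -0.13
- compound 3 `CCC[C@H](c1ccc(C(=O)O)c(Oc2cccc(Cl)c2)c1OC)N1CCC[C@H](n2cc(C)c(=O)[nH]c2=O)C1`: 0.08

These three values lie within the usual scatter of one another, so compound 1 does not stand apart from the other two. Compound 4 `Cc1cn([C@H]2CCCN([C@@H](CC(C)C)c3ccc(C(=O)O)c(Oc4cccc(Cl)c4)c3F)C2)c(=O)[nH]c1=O` has not been measured and differs from compound 1 in one place: isopropyl in place of methyl on a saturated chain carbon, two bonds along the chain from an amine nitrogen in a ring and an aromatic carbon. The same difference, cut one bond further out, reads ethyl to isobutyl.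

Within the data shown here, only one measured change resembles this, a methyl in place of hydrogen on a saturated chain carbon: a number 0.21 log units higher from compound 2 to compound 3 (within the scatter). Among the measured compounds shown here, it is a single step within the scatter, on a different core, and no measured compound carries isobutyl, so the guidance is weak. More carbon enters here, so a somewhat larger upward change is expected, estimated as a number 0.39 log units higher from compound 1 to compound 4 (beyond the scatter). For compound 4 the expected value is 0.5, with an estimated range from 0.15 to 0.9.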

Compound 4, distribution coefficient: 0.57
Compound 4: the middle estimate sits 0.07 log units below what was measured; the range from low to high includes it.
By their numbers in this assay, from the lowest: compounds 2, 3 and 1 (each within the scatter of the next); then compound 4.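

In this assay, among these compounds, isopropyl in place of methyl at this saturated chain carbon gives the first step beyond the scatter: a number 0.46 log units higher from compound 1 to compound 4 (beyond the scatter). Among the compounds shown here, the only earlier step stayed within the scatter and sat on a different core, so this is the first clear sign that the number responds to a change at this place. Nothing shown explains the rise.

On these data alone, what a longer chain, such as straight-chain butyl, or an amine on this chain would give remains open. So does whether the same change would give a similar step on the core of compound 2.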